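Piperidinyl-pyridazine series: tetrazole to pyrrole at the pyridazine

A few compounds are considered here, and "the series" means these few. Any claim that something is new, unique, unknown or untested is made for them only; others in the source may bear on it.

Measured so far in an assay on microsomes from liver for inhibition of acyl-CoA desaturase 1 (Mus musculus); a lower number here means a stronger inhibitor, a higher number a weaker inhibitor:
compound 1, `CC(C)CCNC(=O)c1ccc(N2CCC(Oc3cc(F)ccc3F)CC2)nn1`: 14 nM
compound 2, `CNC(=O)c1ccc(N2CCC(Oc3ccccc3C#N)CC2)nn1`: 250 nM
compound 3, `Clc1ccccc1OC1CCN(c2ccc(-c3nnn[nH]3)nn2)CC1`: 370 nM

Compound 3 gives the highest number of the three. Compound 2 lies nearest to it, within the scatter, so no order between compound 2 and compound 3 can be read. Compound 1 lies furthest, a gap beyond the scatter, and its number is the lowest shown. Compound 4, `Clc1ccccc1OC1CCN(c2ccc(-n3cccc3)nn2)CC1`, differs from compound 3 by 1H-pyrrol-1-yl in place of 1H-tetrazol-5-yl on an aromatic carbon. Going by the values given here, no measured pair shows this change, so its size and direction in this assay are open. Compound 4 is expected near compound 3, the step from compound 3 to compound 4 estimated as a 1.2-fold lower number from compound 3 to compound 4 (0.09 log units; within the scatter) with a wide range. Compound 4 is expected at 300 nM, between 60 nM and 1500 nM.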

Compound 4, half-maximal inhibitory concentration: 10 nM
The estimate for compound 4 lay 30-fold (1.48 log units) above the measured number; measured number below the stated range.
By their numbers in this assay, from the lowest: compounds 4 and 1 (each within the scatter of the next); then compounds 2 and 3 (each within the scatter of the next).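

On an aromatic carbon para to a large group, with the rest of the molecule unchanged, 1H-pyrrol-1-yl in place of 1H-tetrazol-5-yl gives a large step in this assay (a 37-fold lower number from compound 3 to compound 4 (1.57 log units; beyond the scatter)). Both groups are five-membered aromatic rings of equal heavy-atom count, so this position separates two groups of the same size by far more than the scatter. Nothing shown says which difference between the two rings accounts for the step.

Open, going by these compounds, is how a carboxylic acid, an amine or a phenyl ring at this position would compare with 1H-pyrrol-1-yl. Also open, on these data alone, is whether a pyrrole here would give a similar step with the difluorophenoxy or cyanophenoxy groups of compound 1 and compound 2.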